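The source may report more compounds than this note shows. Statements on the series, on what has been measured and on what is new or still open speak of the compounds shown alone.

Measured so far in a functional assay on HCT-116 cells (Homo sapiens) for cytotoxicity, read by MTT assay, with a stated time of 72 h; on this read-out lower numbers stand for stronger inhibition and higher numbers for weaker inhibition:
Compound 1 `NS(=O)(=O)c1cc(-c2nnc(CN3CCN(c4ccccc4)CC3)o2)c(Cl)cc1SCc1ccccc1` gives 105000 nM.
Compound 2 `CCOC(=O)c1cn(Cc2nnc(-c3cc(S(N)(=O)=O)c(SCc4ccccc4)cc3Cl)o2)nn1` gives 108000 nM.

Compound 2 carries the highest of the two numbers; its nearest neighbour is compound 1, and the step of a 1.0-fold higher number from compound 1 to compound 2 (0.01 log units; within the scatter) lies within the scatter, so the two compounds cannot be told apart on these data.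

Compound 3 `NC(=O)c1cn(Cc2nnc(-c3cc(S(N)(=O)=O)c(SCc4ccccc4)cc3Cl)o2)nn1` has not yet been measured in this assay. It differs from compound 2 by amino in place of ethoxy on a carbonyl carbon, with everything else in compound 2 kept. Going by the values given here, no measured step touches this carbonyl carbon. Among the compounds with values here, the only step recorded, a 1.0-fold higher number from compound 1 to compound 2 (0.01 log units; within the scatter), exchanges the whole group on the saturated chain carbon bound to an aromatic carbon and leaves the number where it was; it says nothing specific about an exchange at the carbonyl. Within the data shown here, the series so far shows two weak numbers that do not move with a large change in that part of the molecule, and a smaller change at the edge of the same group is therefore not expected to move the number beyond the scatter in either direction. The step from compound 2 to compound 3 is expected to be no change at the digits printed from compound 2 to compound 3 (within the scatter). For compound 3 the estimated value is 108000 nM, with a range from 50000 nM to 230000 nM.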

Compound 3, half-maximal inhibitory concentration: 72000 nM
The estimate for compound 3 lay 1.5-fold (0.18 log units) above the measured number; low and high end bracket the measured number.
By their numbers in this assay, from the lowest: compounds 3, 1 and 2 (each within the scatter of the next).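

In this assay, going by these compounds alone, ethoxy to amino on the carbonyl carbon gives a 1.5-fold lower number from compound 2 to compound 3 (0.18 log units; within the scatter), the first reading at this carbonyl carbon: turning ethoxycarbonyl into carbamoyl does not separate the two compounds. The larger exchange, 4-carbamoyl-1H-1,2,3-triazol-1-yl in place of 4-phenylpiperazin-1-yl on the saturated chain carbon, gives a 1.5-fold lower number from compound 1 to compound 3 (0.16 log units; within the scatter), so a second triazolyl group also stays level with the phenylpiperazinyl compound. All three compounds now sit within the scatter of one another, so neither the carbonyl substituent nor the group on the chain carbon has yet shown any measurable effect on the number, and no ranking can be drawn.

Open, on these data alone, is whether a free carboxylic acid or a longer alkyl ester at this carbonyl carbon, or an N-methyl amide in place of the carbamoyl, would give a number beyond the scatter. Also open, as far as these compounds go, is whether any group on the saturated chain carbon, such as a simple amine like morpholine, would move the number away from this weak range. Nothing available on these compounds speaks to why the numbers stay together.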